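A few compounds are considered here, and "the series" means these few. Any claim that something is new, unique, unknown or untested is made for them only; others in the source may bear on it.

Measured in a functional assay on KB cells (Homo sapiens) for cytotoxicity; a lower number here means a stronger inhibitor, a higher number a weaker inhibitor:
- compound 1 `COC(=O)c1ccc(C(=O)Nc2cccc3c2N(S(=O)(=O)c2ccc(OC)cc2)CC3)cc1` gives 376 nM
- compound 2 `COc1ccc(S(=O)(=O)N2CCc3cccc(NC(=O)c4ccc([N+](=O)[O-])cc4)c32)cc1` gives 102 nM
- compound 3 `COc1ccc(S(=O)(=O)N2CCc3cccc(NC(C)=O)c32)cc1` gives 89 nM

Compound 3 sits level with compound 2 within the scatter, while the gap to compound 1 is real: a 4.2-fold lower number from compound 1 to compound 3 (0.63 log units; beyond the scatter). The next compound to test is compound 4 `COc1ccc(S(=O)(=O)N2CCc3cccc(NC(=O)c4ccc(C#N)cc4)c32)cc1`, which has 4-cyanophenyl in place of methyl on a carbonyl carbon.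

Two measured steps make the same kind of swap in reverse. One, with 4-nitrophenyl, is a 1.1-fold lower number from compound 2 to compound 3 (0.06 log units; within the scatter). The other, with 4-(methoxycarbonyl)phenyl, is the modest step already given. So the group carried on the ring matters, as a 3.7-fold lower number from compound 1 to compound 2 (0.57 log units; beyond the scatter) also shows. Nothing measured yet shows which of the two compound 4 will follow. Compound 2 is taken as the closer guide, but this is a judgement, with some allowance made for compound 1. In this assay the expected change is therefore small, a slightly higher number at most near the edge of the scatter: a 1.5-fold higher number from compound 3 to compound 4 (0.16 log units; within the scatter). The estimate for compound 4 is 130 nM, with an expected range from 50 nM to 340 nM.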

Compound 4, half-maximal inhibitory concentration: 105 nM
Compound 4: middle estimate off by 1.2-fold (0.09 log units), on the high side, within the range that was stated.
By their numbers in this assay, from the lowest: compounds 3, 2 and 4 (each within the scatter of the next); then compound 1.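

In this assay, the step from a single-carbon methyl to 4-cyanophenyl on the carbonyl carbon is within the scatter (a 1.2-fold higher number from compound 3 to compound 4 (0.07 log units; within the scatter)), so compound 4 adds a second ring-bearing group, after the 4-nitrophenyl of compound 2, that matches the small acetyl compound. On the aromatic carbon, cyano and nitro cannot be told apart (a 1.0-fold higher number from compound 2 to compound 4 (0.01 log units; within the scatter)), while cyano in place of methoxycarbonyl gives a real change (a 3.6-fold lower number from compound 1 to compound 4 (0.55 log units; beyond the scatter)), leaving compound 1 as the one that stands apart among the compounds carrying this ring. Nothing measured here explains these results.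

Still open, going by these compounds, is whether an amine or a carboxylic acid in place of the cyano would track compound 4 or compound 1. A longer chain in place of the methyl on the carbonyl carbon is also untested in the compounds shown.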